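Removing a methyl group from compound 3

A few compounds are considered here, and "the series" means these few. Any claim that something is new, unique, unknown or untested is made for them only; others in the source may bear on it.

Compound 1 `Cc1cn([C@@H]2S[C@H](CO)[C@H]2CO)c(=O)[nH]c1=O`: > 100000 nM, a limit of the assay
Compound 2 `O=c1ccn([C@@H]2S[C@H](CO)[C@H]2CO)c(=O)[nH]1`: 4900 nM
Compound 3 `Cc1cn([C@H]2S[C@@H](CO)[C@@H]2CO)c(=O)[nH]c1=O`: > 100000 nM, a limit of the assay

All three were tested in a functional assay on CCRF-CEM cells (Homo sapiens) for cytotoxicity; a higher number here means a weaker inhibitor, a lower number a stronger inhibitor. In this assay compound 3 gives > 100000 nM. That value is a limit and not a number, so compound 3 has no readable place on the scale. It stands at the limit of > 100000 nM in this assay, at which 2 of the 3 values shown sit.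

The structure that follows is compound 4 `O=c1ccn([C@H]2S[C@@H](CO)[C@@H]2CO)c(=O)[nH]1`, and the change is hydrogen in place of methyl on an aromatic carbon. The same replacement has been measured once, as an at least 20-fold lower number from compound 1 to compound 2 (1.30 log units; beyond the scatter). That large step is the closest guide, and it points to a lower number. The other measured step is a step that the two limits leave unreadable from compound 1 to compound 3, which rests on (the fact that compounds 1 and 3 differ only in the configuration as drawn). It leaves the effect of configuration unknown, so the data cannot show whether the replacement acts with the same size in the mirror-image series. A reading at the limit remains quite possible for compound 4.

A step of uncertain size towards a lower number is expected, estimated as an at least 3.3-fold lower number from compound 3 to compound 4 (0.52 log units; beyond the scatter). Compound 4 is expected at 30000 nM, with an estimated range from 5000 nM to 100000 nM.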

Compound 4, half-maximal inhibitory concentration: > 100000 nM
Compound 4: a limit, no number (the forecaster's own chance of this, stated with the estimate: 45%); middle value at least 3.3-fold (0.52 log units) from the limit.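

In this assay, the loss of the methyl group does not bring the mirror-image series onto the readable scale: compound 4 sits at a limit of the assay, and the steps that end or start at such limits on both sides cannot be read. The new information lies in the pair without the methyl group, where configuration now has a readable size, an at least 20-fold higher number from compound 2 to compound 4 (1.30 log units; beyond the scatter), and this step can be put down to configuration alone because of what separates the two compounds: the fact that compounds 2 and 4 differ only in the configuration as drawn. Among the compounds shown, a clearly lower number on replacing methyl with hydrogen on this aromatic carbon therefore appears only in the step to compound 2, and compound 4 gives it no support in the other series.

From the compounds shown here alone, whether the replacement has any effect at all of compound 3 and compound 4 stays open, since anything beyond the limit is hidden. Also open, going by these compounds, is whether an ethyl group, a bromine atom or an amine on the same aromatic carbon would give a readable value in either series.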